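Aryl hydrazone ureas: hydroxyphenyl replacing dichlorophenyl

The compounds below may be only part of what the source reports. "The series", "measured", "known", "first", "only" and "open" are said of these compounds alone.

Measured so far:
- compound 1, `COc1cc2c(Oc3ccc(NC(=O)N/N=C/c4ccc([N+](=O)[O-])cc4)cc3F)ccnc2cc1OCCCN1CCCC1`: 460 nM
- compound 2, `COc1ccc(/C=N/NC(=O)Nc2ccc(Oc3ccnc4cc(OCCCN5CCCCC5)c(OC)cc34)c(F)c2)cc1`: 540 nM
- compound 3, `COc1cc2c(Oc3ccc(NC(=O)N/N=C/c4ccc(Cl)cc4Cl)cc3F)ccnc2cc1OCCCN1CCCCC1`: "not determined" (no result reported)

The read-out throughout is a functional assay on A549 cells (Homo sapiens) for cytotoxicity, read by MTT assay, with a stated time of 72 h; a higher number here means a weaker inhibitor, a lower number a stronger inhibitor. In this assay compound 1 gives 460 nM and compound 2 gives 540 nM; these two numbers sit within the usual scatter of each other, so no order between them can be drawn. Compound 3 carries a 2,4-dichlorophenyl on the carbon with a double bond to nitrogen, but it has no single number in this assay, so it stands only as the structural neighbour of the next compound, not as a reference point on the scale.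

Compound 4, `COc1cc2c(Oc3ccc(NC(=O)N/N=C/c4ccc(O)cc4)cc3F)ccnc2cc1OCCCN1CCCCC1`, differs from compound 3 in one place: 4-hydroxyphenyl in place of 2,4-dichlorophenyl on a carbon with a double bond to nitrogen. No step between two measured compounds in this series touches this position, so the size and direction of the effect cannot be read from the data; the two measured compounds, which carry a nitrophenyl and a methoxyphenyl there, lie close together, which gives no reason to expect a step beyond the scatter. Compound 4 is therefore expected to give about 550 nM in this assay, with an estimated range from 150 nM to 2500 nM.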

Compound 4, half-maximal inhibitory concentration: 780 nM
The estimate for compound 4 lay 1.4-fold (0.15 log units) below the measured number; the range from low to high includes it.
By their numbers in this assay, from the lowest: compounds 1, 2 and 4 (each within the scatter of the next).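

In this assay this position now has a step between two measured compounds: a 1.4-fold higher number from compound 2 to compound 4 (0.16 log units; within the scatter) with hydrogen in place of methyl on the oxygen on the aromatic ring. In this single pair, the change from a methoxyphenyl to 4-hydroxyphenyl, which brings a hydrogen-bond donor on that ring, produces no shift beyond the scatter, so capping that oxygen with methyl is not shown to matter for this read-out. No measurement shown here gives a reason for this result.

Going by these compounds, compound 3 has no single number, so the step from it to compound 4 cannot be read, and what 2,4-dichlorophenyl does on the carbon with a double bond to nitrogen stays unknown. Also open, on these data alone, is whether a phenyl carrying an amine or a carboxylic acid, or a longer chain on the oxygen of the hydroxyphenyl, would stay within the scatter of compound 4 or move clearly away from it.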